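A few compounds are considered here, and "the series" means these few. Any claim that something is new, unique, unknown or untested is made for them only; others in the source may bear on it.

Going by the values given here, in an in vivo ADME assay on the whole organism (plasma, Rattus norvegicus) for pharmacokinetics (on this read-out lower numbers stand for slow clearance and higher numbers for fast clearance), compound 1 `NS(=O)(=O)c1ccccc1-c1ccc(C(=O)NCCC(=O)Nc2ccc(Br)cn2)cc1` gives 35 mL/min/kg and compound 2 `NS(=O)(=O)c1ccccc1-c1ccc(C(=O)NC(CC(=O)Nc2ccc(Br)cn2)C(=O)O)cc1` gives 6.7 mL/min/kg, the lowest of the two numbers so far. Next in line is compound 3 `NS(=O)(=O)c1ccccc1-c1ccc(C(=O)NC(CC(=O)Nc2ccc(Br)cn2)C(=O)N2CCCCC2)cc1`, with the change piperidin-1-yl in place of hydroxy on a carbonyl carbon, which turns carboxy into (piperidin-1-yl)carbonyl. Among the compounds with values here, no measured step covers this exact change. Within the data shown here, the one step that bears on it is a 5.2-fold lower number from compound 1 to compound 2 (0.72 log units; beyond the scatter), beyond the scatter, where carboxy came in place of hydrogen on a saturated chain carbon. Compound 3 no longer carries that carboxy, so a move back towards compound 1 at 35 mL/min/kg is expected, of similar or somewhat smaller size than that step and towards a higher number. The estimated change is a 3.6-fold higher number from compound 2 to compound 3 (0.55 log units; beyond the scatter). For compound 3 the expected clearance is 24 mL/min/kg, with an estimated range of 10 mL/min/kg to 58 mL/min/kg.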

Compound 3, clearance: 50.6 mL/min/kg
For compound 3 the middle estimate is 2.1-fold (0.32 log units) below the measured one, and the stated range covers the measured number.
By their numbers in this assay, from the lowest: compound 2; then compounds 1 and 3 (each within the scatter of the next).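

In this assay, the low number of compound 2 does not carry over when piperidin-1-yl takes the place of hydroxy on the carbonyl carbon (a 7.6-fold higher number from compound 2 to compound 3 (0.88 log units; beyond the scatter)), so a substituent at this chain carbon does not by itself give a low clearance. Set against the unsubstituted chain, (piperidin-1-yl)carbonyl in place of hydrogen gives no separation (a 1.4-fold higher number from compound 1 to compound 3 (0.16 log units; within the scatter)), and among these three compounds only compound 2, with its carboxy, stands apart. No measurement available here accounts for this difference.

As far as these compounds go, whether a primary amide, a methyl ester or a smaller dimethylamino group on the same carbonyl carbon would read like compound 2 or like compound 3 remains open. From the compounds shown here alone, it is also open whether a carboxylic acid placed on a longer chain would give the low number of compound 2.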